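The compounds below may be only part of what the source reports. "The series", "measured", "known", "first", "only" and "open" are said of these compounds alone.

Measured in an ADME assay on BJ cells (Homo sapiens) for inhibition, with a stated time of 72 h (a higher number here means that more compound is needed for the effect, a lower number that less compound is needed), so far:
compound 1 `O=C(CCl)Nc1cccc(-c2nc3ccccc3s2)c1` gives 8500 nM
compound 2 `CC(C)(CCl)C(=O)Nc1cccc(-c2nc3ccccc3s2)c1` gives > 25000 nM, a limit of the assay
compound 3 `O=C(Nc1cccc(-c2nc3ccccc3s2)c1)c1cc([N+](=O)[O-])cnc1Cl` gives > 25000 nM, a limit of the assay

Compound 2 stands at the top of the numbers shown: in this assay it reports only a limit and no number. Among the compounds with values here, the single measured step that reaches it, an at least 2.9-fold higher number from compound 1 to compound 2 (0.46 log units; beyond the scatter), is itself a lower bound on the change, since it ends at the limit of > 25000 nM in this assay, at which 2 of the 3 values shown sit. Compound 3 also sits at that same limit in this assay, so two of the three values shown give no number.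

Compound 4 `O=C(Nc1cccc(-c2nc3ccccc3s2)c1)c1cnc(Cl)s1` differs from compound 2 by 2-chloro-1,3-thiazol-5-yl in place of 1-(chloromethyl)-1-methylethyl on a carbonyl carbon. Within the data shown here, no measured step covers this change. Among the measured compounds shown here, compound 3 is the only other compound carrying an aromatic ring on the carbonyl carbon, and its value in this assay is a limit; compound 1, the only compound with a number, carries chloromethyl there. On that basis compound 4 is expected to remain at or close to the limit, so a step that the limit leaves unreadable from compound 2 to compound 4 is expected to be no step beyond the scatter. Compound 4 is estimated at 30000 nM in this assay, within a range from 8000 nM to 120000 nM.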

Compound 4, half-maximal effective concentration: > 25000 nM
Compound 4: only a limit was reported; the forecaster's own chance of this, stated with the estimate: 70%; the middle value does not contradict the limit.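

With 2-chloro-1,3-thiazol-5-yl in place of chloromethyl on the carbonyl carbon, this assay shows an at least 2.9-fold higher number from compound 1 to compound 4 (0.46 log units; beyond the scatter); this is a lower bound on the change, and it shows that a five-membered aromatic ring at this position, like the open-chain 1-(chloromethyl)-1-methylethyl, gives a step beyond the scatter from chloromethyl. The steps that join two limits cannot be read, so the swap of 1-(chloromethyl)-1-methylethyl for 2-chloro-1,3-thiazol-5-yl has no readable size and gives no order between those two groups. Compound 1 remains the only compound shown with a number, and the limit now covers the rest of the series: the limit of > 25000 nM in this assay, at which 3 of the 4 values shown sit.

Going by these compounds, it remains open whether any group other than chloromethyl on this carbonyl carbon can give a number in this assay, for instance a longer chain such as 2-chloroethyl, an aminomethyl group or a plain methyl. On these data alone, it is also open whether the chlorine of the thiazole counts at all, which a thiazol-5-yl ring without chlorine or a phenyl ring on the carbonyl carbon could begin to answer, provided the value is a number and not a limit.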